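The compounds below may be only part of what the source reports. "The series", "measured", "known", "first", "only" and "open" are said of these compounds alone.

Notes on the series. Compound 1 `CC(C)N(Cc1cccc(OCCCCCC(=O)O)c1)C(=O)c1ccc(-c2cccc3ccccc23)cc1` is the naphthalen-1-yl member; in an ADME assay on BJ cells (Homo sapiens) for cytotoxicity, read by CellTiter-Glo and resazurin assay, with a stated time of 72 h (a higher number here means that more compound is needed for the effect, a lower number that less compound is needed), compound 1 gives < 1.3 nM, which is a limit of the assay and not a number. Compound 2 `CC(=O)c1cccc(-c2ccc(C(=O)N(Cc3cccc(OCCCCCC(=O)O)c3)C(C)C)cc2)c1` carries 3-acetylphenyl in place of naphthalen-1-yl on an aromatic carbon, and in this assay compound 2 gives > 26000 nM, again a limit. Compound 3 `Cc1nnc(-c2cccc(-c3ccc(C(=O)N(Cc4cccc(OCCCCCC(=O)O)c4)C(C)C)cc3)c2)o1` carries 3-(5-methyl-1,3,4-oxadiazol-2-yl)phenyl in place of naphthalen-1-yl on an aromatic carbon; in this assay compound 3 gives > 26000 nM, also a limit. Compound 1 thus stands only at a limit, and the two other values shown are limits as well, namely the limit of < 1.3 nM in this assay, at which 1 of the 3 values shown sits, and (the limit of > 26000 nM in this assay, at which 2 of the 3 values shown sit). The readable steps are an at least 20000-fold higher number from compound 1 to compound 2 (4.30 log units; beyond the scatter) and an at least 20000-fold higher number from compound 1 to compound 3 (4.30 log units; beyond the scatter); the step that the two limits leave unreadable from compound 2 to compound 3 stays unreadable between two limits.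

Compound 4 `COc1cc(OC)cc(-c2ccc(C(=O)N(Cc3cccc(OCCCCCC(=O)O)c3)C(C)C)cc2)c1` differs from compound 1 by 3,5-dimethoxyphenyl in place of naphthalen-1-yl on an aromatic carbon. Both measured replacements of naphthalen-1-yl by a substituted phenyl run the same way and are large, so for compound 4 a large rise in this assay is expected, most likely up to the limit of the limit of > 26000 nM in this assay, at which 2 of the 3 values shown sit, once more. The expected step is an at least 15000-fold higher number from compound 1 to compound 4 (4.18 log units; beyond the scatter). Compound 4 is therefore estimated at 20000 nM, within 2000 nM to 60000 nM.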

Compound 4, half-maximal effective concentration: > 26000 nM
Compound 4: only a limit was reported; the forecaster's own chance of this, stated with the estimate: 60%; middle value at least 1.3-fold (0.11 log units) away from the limit.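

The third substituted phenyl behaves like the other two in this assay: 3,5-dimethoxyphenyl in place of naphthalen-1-yl gives an at least 20000-fold higher number from compound 1 to compound 4 (4.30 log units; beyond the scatter), even though the heavy-atom count of the group is the same on both sides of the change. The large step at this position, para to a large group, therefore does not depend on an acetyl or a 5-methyl-1,3,4-oxadiazol-2-yl group, since a phenyl ring with two methoxy groups and neither of those gives it too. The steps among compound 2, compound 3 and compound 4 cannot be read, all three values being limits of the assay: the limit of > 26000 nM in this assay, at which 3 of the 4 values shown sit.

The compounds shown leave open whether the step follows the loss of the second aromatic ring or the oxygen-bearing substituents on the phenyl ring, as compound 1 is the only member with two such rings and every phenyl member here has oxygen in its substituent. Unsubstituted phenyl, a phenyl carrying only methyl or chlorine, and naphthalen-2-yl at the same place would separate these readings and might fall between the two limits.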